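Taking the hydroxy group off compound 3

The source may report more compounds than this note shows. Statements on the series, on what has been measured and on what is new or still open speak of the compounds shown alone.

Measured in a functional assay on OVCAR-3 cells (Homo sapiens) for inhibition, read by MTT assay, with a stated time of 24 h; on this read-out lower numbers stand for stronger inhibition and higher numbers for weaker inhibition:
Compound 1 `CC1(C)[C@H]2CC[C@]1(C)N(Cc1cn(-c3cccc(F)c3)nn1)C(=O)C2`: 430 nM
Compound 2 `CC1(C)[C@H]2CC[C@]1(C)N(Cc1cn(-c3ccccc3F)nn1)C(=O)C2`: 300 nM
Compound 3 `CC1(C)[C@H]2CC[C@]1(C)N(Cc1cn(-c3ccc(O)cc3)nn1)C(=O)C2`: 410 nM

The three compounds share one core and differ only in the substituted phenyl group on an aromatic nitrogen. In this assay compound 3, at 410 nM, cannot be separated from the other two. Its steps are a 1.0-fold lower number from compound 1 to compound 3 (0.02 log units; within the scatter) and a 1.4-fold higher number from compound 2 to compound 3 (0.14 log units; within the scatter). The two fluorophenyl compounds are no further apart, with a 1.4-fold lower number from compound 1 to compound 2 (0.16 log units; within the scatter).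

Compound 4 `CC1(C)[C@H]2CC[C@]1(C)N(Cc1cn(-c3ccccc3)nn1)C(=O)C2` comes from compound 3 by a single change, hydrogen in place of hydroxy on an aromatic carbon, para to a large group, or 4-hydroxyphenyl to phenyl. For the measured compounds named here, no measured step isolates this change, and none of the measured compounds carries an unsubstituted phenyl. The closest evidence is the pair of exchanges that involve the 4-hydroxyphenyl group, a 1.0-fold lower number from compound 1 to compound 3 (0.02 log units; within the scatter) and a 1.4-fold higher number from compound 2 to compound 3 (0.14 log units; within the scatter). Both stayed within the scatter, though three compounds make a thin basis. On that evidence, no step beyond the scatter is expected in this assay, and no direction can be favoured. The expected size is a 1.1-fold lower number from compound 3 to compound 4 (0.03 log units; within the scatter). Compound 4 is therefore estimated at 380 nM, with an expected range of 190 nM to 760 nM.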

Compound 4, half-maximal inhibitory concentration: 50 nM
Compound 4: middle estimate off by 7.6-fold (0.88 log units), on the high side; the whole stated range lies above it.
By their numbers in this assay, from the lowest: compound 4; then compounds 2, 3 and 1 (each within the scatter of the next).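

In this assay the change from 4-hydroxyphenyl to phenyl turns out to be a real one, with an 8.2-fold lower number from compound 3 to compound 4 (0.91 log units; beyond the scatter) even though the exchanges among the substituted phenyl groups had stayed within the scatter and gave no hint of it. Taking the fluoro group off either fluorophenyl compound goes the same way, with a 6.0-fold lower number from compound 2 to compound 4 (0.78 log units; beyond the scatter) and with an 8.6-fold lower number from compound 1 to compound 4 (0.93 log units; beyond the scatter) as well, so among these four compounds the divide runs between the unsubstituted phenyl of compound 4 and all three substituted rings, with no compound going against it, and not between one substituent and another. No measurement shown here accounts for this divide.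

As far as these compounds go, it remains open whether any group on this ring can match the bare phenyl, since a methyl, a methoxy or an amine para to a large group could either keep the low number of compound 4 or fall back to the level of the other three. Also open, from the compounds shown here alone, is whether the same divide would appear in cell lines other than this one, or at other exposure times.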